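The compounds below may be only part of what the source reports. "The series", "measured", "known", "first", "only" and "open" are said of these compounds alone.

Compound 1 `CSc1ccc(N(C)c2nc(C)nc3ccccc23)cc1`: 1.3 nM
Compound 2 `COc1ccc(N(C)c2ncnc3ccccc23)cc1`: 8.6 nM

In a functional assay on HeLa cells (Homo sapiens) for cytotoxicity, read by sulforhodamine B assay (a lower number here means a stronger inhibitor, a higher number a weaker inhibitor), compound 2 has the higher of the two numbers, which makes it the weaker inhibitor, and its gap to compound 1 lies beyond the usual scatter. Compound 3 `CSc1ccc(N(C)c2ncnc3ccccc23)cc1` is compound 2 with methylsulfanyl in place of methoxy on an aromatic carbon. Within the data shown here, no pair of measured compounds shows this swap alone, so only a small shift towards a lower number can be expected in this assay, none beyond the scatter. The estimated change is a 1.2-fold lower number from compound 2 to compound 3 (0.09 log units; within the scatter). Compound 3 is estimated at 7 nM, with an expected range of 2 nM to 25 nM.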

Compound 3, half-maximal inhibitory concentration: 8.5 nM
Beside the measured number, compound 3's estimate is 1.2-fold (0.08 log units) below it, and the stated range covers the measured number.
By their numbers in this assay, from the lowest: compound 1; then compounds 3 and 2 (each within the scatter of the next).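

In this assay, methylsulfanyl in place of methoxy on this aromatic carbon gives a 1.0-fold lower number from compound 2 to compound 3 (0.01 log units; within the scatter), so the two groups cannot be told apart at this position, para to a large group. Hydrogen in place of methyl on the core gives a 6.5-fold higher number from compound 1 to compound 3 (0.82 log units; beyond the scatter), which shows that this other site, unlike the first, matters in this assay. No measurement shown explains either result.

Going by these compounds, whether an amine or a longer chain such as butoxy would be tolerated at the para position remains open. So does whether the methyl on the core has the same effect alongside methoxy.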